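The compounds below may be only part of what the source reports. "The series", "measured", "known", "first", "only" and "open" are said of these compounds alone.

Removing the methyl from compound 3: expected potency in an assay on microsomes from liver for inhibition of 3-hydroxy-3-methylglutaryl-coenzyme A reductase (Rattus norvegicus), read by scintillation counting, with stated times of 0.5 h and 0.75 h; a lower number here means a stronger inhibitor, a higher number a weaker inhibitor

Measured so far:
compound 1, `O=C(O)C[C@H](O)C[C@H](O)CCn1c(-c2ccc(F)cc2)nc(C(=O)NCc2ccc(F)c(F)c2)c1C1CC1`, gives 1.2 nM
compound 2, `O=C(O)C[C@H](O)C[C@H](O)CCn1c(-c2ccc(F)cc2)nc(C(=O)NCc2cccc(F)c2)c1C1CC1`, gives 1.2 nM
compound 3, `Cc1cccc(CNC(=O)c2nc(-c3ccc(F)cc3)n(CC[C@@H](O)C[C@@H](O)CC(=O)O)c2C2CC2)c1`, gives 7.2 nM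

Compound 3 stands with the highest number of the three. It is separated from both fluoro analogues by steps beyond the scatter: a 6.0-fold higher number from compound 1 to compound 3 (0.78 log units; beyond the scatter) and a 6.0-fold higher number from compound 2 to compound 3 (0.78 log units; beyond the scatter). The two fluoro analogues themselves lie within the scatter of each other, as no change at the digits printed from compound 1 to compound 2 (within the scatter) shows.

Compound 4, `O=C(O)C[C@H](O)C[C@H](O)CCn1c(-c2ccc(F)cc2)nc(C(=O)NCc2ccccc2)c1C1CC1`, differs from compound 3 in one place: hydrogen in place of methyl on an aromatic carbon.

Going by the values given here, two measured steps bear on this change. a 6.0-fold higher number from compound 2 to compound 3 (0.78 log units; beyond the scatter) shows that methyl in place of fluoro on the aromatic carbon costs a modest amount. no change at the digits printed from compound 1 to compound 2 (within the scatter) shows that hydrogen in place of fluoro on an aromatic carbon costs nothing beyond the scatter. Hydrogen and fluoro thus read alike in this assay, while methyl reads worse; the move from methyl to hydrogen is therefore expected to lower the number, recovering part or all of the loss seen at compound 3. A modest step downward is expected, roughly the reverse of a 6.0-fold higher number from compound 2 to compound 3 (0.78 log units; beyond the scatter), though the direct comparison is not yet available.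

Compound 4 is expected to give 3 nM in this assay, within the range 1 nM to 9 nM. This estimate corresponds to an expected step of a 2.4-fold lower number from compound 3 to compound 4 (0.38 log units; beyond the scatter).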

Compound 4, half-maximal inhibitory concentration: 1.4 nM
The estimate for compound 4 lay 2.1-fold (0.33 log units) above the measured number, within the range that was stated.
By their numbers in this assay, from the lowest: compounds 1, 2 and 4 (each within the scatter of the next); then compound 3.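

In this assay, the direct step of a 5.1-fold lower number from compound 3 to compound 4 (0.71 log units; beyond the scatter) ties the loss at compound 3 to the methyl on this aromatic carbon, since taking that single carbon away is enough to undo it. The earlier compounds shown here showed the cost only against fluoro, which left open whether hydrogen would match fluoro on the plain benzyl amide; the steps of a 1.2-fold higher number from compound 2 to compound 4 (0.07 log units; within the scatter) and a 1.2-fold higher number from compound 1 to compound 4 (0.07 log units; within the scatter) now settle this, as neither separates the unsubstituted phenyl from the fluorinated rings. Across these four compounds, fluoro substitution on this ring therefore adds nothing measurable over hydrogen, and compound 3 is the only one that stands apart. Nothing at hand gives a reason for the cost of the methyl.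

As far as these compounds go, whether the cost extends to other carbon or oxygen groups at this place, such as ethyl, methoxy or trifluoromethyl, remains open, as does how a charged group such as an amine or a carboxylic acid would read there. The methyl is also shown at only one place on the ring, so a methyl elsewhere on it stays an open question.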